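Aromatic Side Group Returns at the Saturated Ring Carbon

This account rests on a few compounds, and the source may have more. Where it says the series, first, only, none or still open, it means among the compounds named here.

The three measured compounds share one core and differ only in the group on a saturated ring carbon. Compound 1 `c1ccc2c(c1)CCC2NC1CCN(CCCc2c[nH]c3ccc(-n4cnnc4)cc23)CC1` carries (2,3-dihydro-1H-inden-1-yl)amino; in an assay on CHO cells for displacement of a labelled ligand from 5-hydroxytryptamine receptor 1D (Homo sapiens) (on this read-out lower numbers stand for stronger inhibition and higher numbers for weaker inhibition), compound 1 gives 8.9 nM. Compound 2 `CN(Cc1ccccc1)CC1CCN(CCCc2c[nH]c3ccc(-n4cnnc4)cc23)CC1` carries (benzyl(methyl)amino)methyl, and in this assay compound 2 gives 0.9 nM. Compound 3 `CC(C)=CCN(C)C1CCN(CCCc2c[nH]c3ccc(-n4cnnc4)cc23)CC1` carries methyl(3-methylbut-2-en-1-yl)amino, and in this assay compound 3 gives 0.5 nM, the lowest of the three numbers. Its separation from compound 2 is a 1.8-fold lower number from compound 2 to compound 3 (0.26 log units; within the scatter), within the scatter, whereas the step of an 18-fold lower number from compound 1 to compound 3 (1.25 log units; beyond the scatter) is beyond it.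

Compound 4 `C[C@@H](NCC1CCN(CCCc2c[nH]c3ccc(-n4cnnc4)cc23)CC1)c1ccccc1` differs from compound 3 in one place: ((1-phenylethyl)amino)methyl in place of methyl(3-methylbut-2-en-1-yl)amino on a saturated ring carbon. The step most relevant is a 1.8-fold lower number from compound 2 to compound 3 (0.26 log units; within the scatter), because compound 2 also bears a group containing a six-membered aromatic ring and gives 0.9 nM, close to compound 3; the step of a 9.9-fold lower number from compound 1 to compound 2 (1.00 log units; beyond the scatter) shows that an aromatic group of another shape can give a much higher number, so some spread is possible. Compound 4 is therefore expected to lie near compound 2 and compound 3, with a step of a 2.0-fold higher number from compound 3 to compound 4 (0.30 log units; within the scatter) expected. The estimate for compound 4 is 1 nM, in the range 0.4 nM to 3 nM.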

Compound 4, half-maximal inhibitory concentration: 1.4 nM
Compound 4: middle estimate off by 1.4-fold (0.15 log units), on the low side; the measured number falls inside the stated range.
By their numbers in this assay, from the lowest: compounds 3, 2 and 4 (each within the scatter of the next, the first and the last beyond it); then compound 1.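

In this assay, the step of a 2.8-fold higher number from compound 3 to compound 4 (0.45 log units; beyond the scatter) lies beyond the scatter, so this position does register the exchange of methyl(3-methylbut-2-en-1-yl)amino for ((1-phenylethyl)amino)methyl, a larger group with one six-membered aromatic ring, one hydrogen-bond donor and one defined stereocentre, although the number remains far from that of compound 1. The two groups with a six-membered aromatic ring on a chain carbon cannot be told apart here, as the step of a 1.6-fold higher number from compound 2 to compound 4 (0.19 log units; within the scatter) stays within the scatter for (1-phenylethyl)amino in place of benzyl(methyl)amino, whereas the step of a 6.4-fold lower number from compound 1 to compound 4 (0.80 log units; beyond the scatter) shows that ((1-phenylethyl)amino)methyl and (2,3-dihydro-1H-inden-1-yl)amino are clearly separated. Nothing supplied with these compounds gives a reason for any of these differences.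

The compounds shown leave open how the opposite configuration at the defined stereocentre of compound 4 would read in this assay. They also leave open whether a fluorine or a methoxy group on the six-membered aromatic ring of compound 4 would shift its number.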